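Swapping a chlorinated ring for a trifluoromethyl-bearing one

A few compounds are considered here, and "the series" means these few. Any claim that something is new, unique, unknown or untested is made for them only; others in the source may bear on it.

Four compounds built on one shared core appear here. Compound 1 `COc1ccccc1/C=c1/[nH]c(=O)/c(=C\c2ccccc2OC)n(C)c1=O` carries two methoxyphenyl groups and, in a functional assay on Huh-7 cells (Homo sapiens) for cytotoxicity, read by CCK-8 assay, with a stated time of 72 h (on this read-out higher numbers stand for weaker inhibition and lower numbers for stronger inhibition), compound 1 is reported as "not active" (no number reported). Compound 2 `C=CCn1c(=O)/c(=C\c2cccc(Cl)c2Cl)[nH]c(=O)/c1=C\c1ccccc1OC` carries an allyl group and a 2,3-dichlorophenyl group; in this assay compound 2 gives 1200 nM. Compound 3 `C=CCn1c(=O)/c(=C\c2ccc(Cl)c(Cl)c2)[nH]c(=O)/c1=C\c1ccccc1OC` keeps the allyl group but bears a 3,4-dichlorophenyl group, and in this assay compound 3 is reported as "not active" (no number reported). So compound 3 stands without a single number, and compound 1 is a further entry without one; only compound 2 gives a measurable figure.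

Compound 4 `C=CCn1c(=O)/c(=C\c2ccccc2C(F)(F)F)[nH]c(=O)/c1=C\c1ccccc1OC` is the next step: 2-(trifluoromethyl)phenyl in place of 3,4-dichlorophenyl on a double-bonded chain carbon bound to an aromatic carbon. Since compound 3 gives no number, no step size between the two can be read off. The expectation for compound 4 is shaped by compound 2, whose substituted ring gives 1200 nM, while compound 3 gives "not active" (no number reported), so a measurable but modest figure is expected for compound 4, at 3000 nM with a range from 800 nM to 15000 nM.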

Compound 4, half-maximal inhibitory concentration: 9500 nM
Compound 4: the middle estimate sits 3.2-fold (0.50 log units) below what was measured; the range from low to high includes it.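

In this assay the ring at this position need not carry chlorine for a number to appear: compound 4, with 2-(trifluoromethyl)phenyl, gives 9500 nM and so joins compound 2 among the compounds with a measured figure. Exchanging 2,3-dichlorophenyl for 2-(trifluoromethyl)phenyl brings a 7.9-fold higher number from compound 2 to compound 4 (0.90 log units; beyond the scatter), which on this read-out means weaker inhibition. Compound 3 has no number, so the step from it to compound 4 cannot be read.

No supporting measurement explains why this exchange shifts the number. Still open, as far as these compounds go, is whether a ring bearing an amine, a carboxylic acid or a simple methyl group on this double-bonded chain carbon would give a lower number than the dichlorophenyl ring of compound 2.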